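The source may report more compounds than this note shows. Statements on the series, on what has been measured and on what is new or still open speak of the compounds shown alone.

Compound 1 `ClCc1ccc(Cn2cnc3c(Cl)ncnc32)cc1` gives 1620 nM in a functional assay on MDA-MB-435 cells (Homo sapiens) for cytotoxicity, read by sulforhodamine B assay, with a stated time of 48 h; on this read-out lower numbers stand for stronger inhibition of growth and higher numbers for weaker inhibition of growth. Compound 2 `ClCc1cccc(Cn2cnc3ncnc(Cl)c32)c1` gives 3460 nM. Compound 3 `ClCc1cccc(Cn2cnc3c(Cl)ncnc32)c1` gives 1690 nM.

Among these three, compound 2 carries the highest number, so it is the weakest inhibitor of growth shown; its nearest neighbour on the numbers is compound 3, and compound 1 sits furthest from it, both differences lying beyond the usual scatter. Compound 4 `ClCc1cccc(Cn2cnc3nc(Cl)nc(Cl)c32)c1` is the as-yet-unmeasured partner of compound 2: the change is chloro in place of hydrogen on an aromatic carbon, between two ring nitrogen atoms, meta to a chloro group. No measured pair shows this change, so the direction rests on no shown step; a small step toward a lower number, not clearly beyond the scatter, is expected in this assay. Compound 4 is therefore estimated at 2500 nM, with a range from 800 nM to 8000 nM, an expected step of a 1.4-fold lower number from compound 2 to compound 4 (0.14 log units; within the scatter).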

Compound 4, concentration for 50% growth inhibition: 1470 nM
Beside the measured number, compound 4's estimate is 1.7-fold (0.23 log units) above it, and the stated range covers the measured number.
By their numbers in this assay, from the lowest: compounds 4, 1 and 3 (each within the scatter of the next); then compound 2.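

In this assay, chloro in place of hydrogen on the aromatic carbon between two ring nitrogen atoms gives the first step seen at this position (a 2.4-fold lower number from compound 2 to compound 4 (0.37 log units; beyond the scatter)). The step runs toward stronger inhibition of growth, so a chloro group here does not cost activity, although this rests on a single modest pair. Nothing shown gives a reason for this step. From the compounds shown here alone, whether an amine or a methoxy group at this position would move the number the same way remains open, and so does whether the step would recur on another core.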